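A few compounds are considered here, and "the series" means these few. Any claim that something is new, unique, unknown or untested is made for them only; others in the source may bear on it.

Measured so far in an assay on isolated protein for inhibition of histone deacetylase 8 (Homo sapiens), read by fluorescence, with stated times of 5 min and 30 min; on this read-out lower numbers stand for stronger inhibition and higher numbers for weaker inhibition:
compound 1 `O=C(CCCCn1cc(Nc2ncc(Cl)c(Nc3ccc(F)cc3)n2)cn1)NO`: compound 1 gives 5100 nM
compound 2 `O=C(CCCCCn1cc(Nc2ncc(Cl)c(Nc3ccc(Cl)cc3)n2)cn1)NO`: compound 2 gives 2470 nM

Compound 1 holds the higher of the two numbers in this assay. Compound 2, which differs from compound 1 in more than one place, gives the lower value, and the gap between the two lies beyond the usual scatter. Among the measured compounds shown here, no single-change step between measured compounds exists, so the pair shows only that the second compound inhibits more strongly; which of its changes carries that is not known.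

Compound 3 `O=C(CCCCCCCn1cc(Nc2ncc(Cl)c(Nc3ccc(F)cc3)n2)cn1)NO` has not been measured. It keeps the rest of compound 1 unchanged and differs only as follows: 3-(hydroxycarbamoyl)propyl in place of hydroxycarbamoyl on a saturated chain carbon, four bonds along the chain from an aromatic nitrogen. The chain between the aromatic nitrogen and the hydroxamic acid therefore grows. For the measured compounds named here, no measured step isolates such a chain extension. Compound 2 carries a somewhat longer chain than compound 1 and gives the lower number, but its second change prevents any firm reading of direction. A modest lowering of the number is expected, possibly beyond the scatter, with wide uncertainty. Compound 3 is estimated at 2200 nM, range 600 nM to 8000 nM. The expected step is a 2.3-fold lower number from compound 1 to compound 3 (0.37 log units; beyond the scatter).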

Compound 3, half-maximal inhibitory concentration: 1700 nM
Compound 3: middle estimate off by 1.3-fold (0.11 log units), on the high side; low and high end bracket the measured number.
By their numbers in this assay, from the lowest: compounds 3 and 2 (each within the scatter of the next); then compound 1.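

In this assay, 3-(hydroxycarbamoyl)propyl in place of hydroxycarbamoyl on a saturated chain carbon, four bonds along the chain from an aromatic nitrogen, gives a 3.0-fold lower number from compound 1 to compound 3 (0.48 log units; beyond the scatter). Among the compounds shown here, this is the first reading of chain length with the rest of compound 1 held fixed, and it shows that the longer chain lowers the number by more than the usual scatter, a direction that compound 2 could not establish, as it differs from compound 1 in more than one place. No measurement on hand accounts for this step, so the result stands as an observed change in inhibition only.

With only two chain lengths compared directly, the compounds shown do not tell whether the number falls steadily along the chain, whether the intermediate lengths behave differently, or whether a still longer chain would lower it further or reverse the trend. They also leave open whether the same step holds with the substituent of compound 2 in place of the fluorine of compound 1, and how a carboxylic acid would read in place of the hydroxamic acid at the chain end.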